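Aminofluoropyridyl in place of cyanofluorophenyl on a thiazole

The source may hold more compounds than are shown below. What is called first, only, known or untested is meant among the compounds shown, and "the series" means these compounds.

Measured compounds:
compound 1, `N#Cc1cc(-c2nc(C(c3ccc(F)cc3)c3ccc(F)cc3)sc2CC(=O)O)ccc1F`, 520 nM
compound 2, `Nc1nc(-c2ccc(Cl)cc2)c(CC(=O)O)s1`, > 100000 nM

Going by the values given here, in an in vitro functional assay on HEK285-7 cells for antagonist activity at prostaglandin D2 receptor 2 (Homo sapiens), read by BRET and beta-arrestin recruitment (a lower number here means a stronger inhibitor, a higher number a weaker inhibitor), compound 1 gives 520 nM, and this is the only number on record. Compound 2, with its own structure, reaches only a limit in this assay, namely > 100000 nM, so that the limit of > 100000 nM in this assay, at which 1 of the 2 values shown sits, describes where it sits. Among the compounds with values here, compound 1 and compound 2 differ in several places at once, so their two values show only that one is a number and the other a limit.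

The unmeasured compound 3 has the structure `Nc1cc(-c2nc(C(c3ccc(F)cc3)c3ccc(F)cc3)sc2CC(=O)O)cc(F)n1`. It arises from compound 1 by 2-amino-6-fluoropyridin-4-yl in place of 3-cyano-4-fluorophenyl on an aromatic carbon. The group that leaves and the group that enters are both aromatic six-membered rings carrying a fluorine, but the entering ring holds a hetero atom and an amino group. Within the data shown here, no measured pair isolates a change of this kind, so no step is available to lean on. The step from compound 1 to compound 3 is expected to be a modest loss beyond the scatter, a 2.9-fold higher number from compound 1 to compound 3 (0.46 log units; beyond the scatter). Compound 3 is therefore estimated at 1500 nM, within 300 nM to 8000 nM.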

Compound 3, half-maximal inhibitory concentration: 1400 nM
The estimate for compound 3 lay 1.1-fold (0.03 log units) above the measured number; measured number inside the range.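

Going by these compounds alone, the pair of compound 1 and compound 3 gives the first step that changes one place only. In this assay, putting 2-amino-6-fluoropyridin-4-yl in place of 3-cyano-4-fluorophenyl gives a 2.7-fold higher number from compound 1 to compound 3 (0.43 log units; beyond the scatter). The aromatic carbon next to the ring nitrogen and next to the ring atom that bears a carboxymethyl group therefore accepts a ring with a hetero atom and an amino group and without the nitrile, at a modest loss, and compound 3 still gives a measured number, 1400 nM in this case, and not a limit. Nothing on record accounts for the size of this step.

The exchange removes the nitrile and brings in the ring nitrogen and the amino group all at once, so the compounds shown do not divide the loss among these parts. Going by these compounds, whether a pyridyl ring with no amino group, or a phenyl ring carrying an amine, would stay closer to compound 1 or to compound 3 remains open, as does the effect of a methoxy group on the same ring.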